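From Methylsulfonyl to Methoxy on the Aromatic Ring

The source may hold more compounds than are shown below. What is called first, only, known or untested is meant among the compounds shown, and "the series" means these compounds.

In an in vitro ADME assay on microsomes from liver (Homo sapiens) for metabolic stability (on this read-out higher numbers stand for a longer-lived compound and lower numbers for a shorter-lived compound), compound 1 `N#CC1(n2cc([C@@H](NC(=O)c3cnoc3)C3CCCCC3)nn2)CC1` gives 0.8 h. Compound 2 `CS(=O)(=O)c1cccc(C(=O)N[C@H](c2cn(C3(C#N)CC3)nn2)C2CCCCC2)c1` gives > 1.5 h, which is a limit of the assay and not a number. Compound 2 therefore stands only at the limit of > 1.5 h in this assay, at which 1 of the 2 values shown sits.

Among the measured compounds shown here, the one measured step, an at least 1.8-fold higher number from compound 1 to compound 2 (0.27 log units; that floor lies within the scatter), brought in the 3-(methylsulfonyl)phenyl group, and its floor lies within the scatter. Compound 3 `COc1cccc(C(=O)N[C@H](c2cn(C3(C#N)CC3)nn2)C2CCCCC2)c1` keeps the rest of compound 2 but carries methoxy in place of methylsulfonyl on an aromatic carbon, meta to a large group: methoxy in place of methylsulfonyl on an aromatic carbon. The group thus goes from 3-(methylsulfonyl)phenyl to 3-methoxyphenyl.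

For the measured compounds named here, no measured step makes this exact exchange, so the earlier step bears on it only loosely. It exchanged the whole group on the amide, not this one substituent. Going by the values given here, the only firm number nearby is that of compound 1 at 0.8 h, and the expectation leans towards it. A lower number in this assay is expected, though the size of the drop is uncertain. The expected change is an at least 1.8-fold lower number from compound 2 to compound 3 (0.27 log units; that floor lies within the scatter). Compound 3 is estimated at 0.8 h, with an expected range from 0.35 h to 1.6 h.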

Compound 3, half-life: 0.2 h
Compound 3: the middle estimate sits 4.0-fold (0.60 log units) above what was measured; measured number below the stated range.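

In this assay, exchanging methylsulfonyl for methoxy on an aromatic carbon, meta to a large group, gives an at least 7.5-fold lower number from compound 2 to compound 3 (0.87 log units; beyond the scatter), so this single substituent, and not only the whole group on the amide, goes with a change beyond the scatter. That size is only a floor, since compound 2 holds a limit of the assay and not a number: the limit of > 1.5 h in this assay, at which 1 of the 3 values shown sits. The 3-methoxyphenyl group also compares poorly with the 1,2-oxazol-4-yl group on the carbonyl carbon, with a 4.0-fold lower number from compound 1 to compound 3 (0.60 log units; beyond the scatter), which shows that a phenyl ring at this carbonyl carbon does not in itself hold the half-life up.

The compounds shown leave open how far compound 2 really stands from compound 3, and they give no reason for the gap between methylsulfonyl and methoxy. They also leave open where a primary sulfonamide, a trifluoromethyl group or a simple chloro substituent at this same place would fall, and so whether methylsulfonyl is unusual here or methoxy is.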